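1,3-Benzothiazol-2-yl in place of phenyl on sulfur

The source may hold more compounds than are shown below. What is called first, only, known or untested is meant among the compounds shown, and "the series" means these compounds.

Going by the values given here, in a functional assay on HepG2 cells (Homo sapiens) for cytotoxicity, read by MTT assay, with a stated time of 48 h (on this read-out higher numbers stand for weaker inhibition and lower numbers for stronger inhibition), compound 1 `CC1=NN(C(=O)CSc2ccccc2)[C@@H](c2cc(Br)cc(Br)c2O)C1` gives 10400 nM and compound 2 `CCCCSCC(=O)N1N=C(c2cc3ccccc3oc2=O)C[C@@H]1c1ccccc1` gives 6640 nM as two values within the scatter of each other, so compound 1 stands level with the only other measured compound. Compound 3 `CC1=NN(C(=O)CSc2nc3ccccc3s2)[C@@H](c2cc(Br)cc(Br)c2O)C1` differs from compound 1 1,3-benzothiazol-2-yl in place of phenyl on a sulfur with 1,3-benzothiazol-2-yl in place of phenyl on a sulfur. Among the compounds with values here, no measured step in this assay covers this change, so the expectation stays loose. A small move toward stronger inhibition is expected for the step of a 1.7-fold lower number from compound 1 to compound 3 (0.24 log units; within the scatter) and it may not clear the scatter. For compound 3 the estimated value is 6000 nM with an expected range from 2500 nM to 14000 nM on this read-out.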

Compound 3, half-maximal inhibitory concentration: 8700 nM
Estimate against measurement, compound 3: 1.5-fold (0.16 log units) below, within the range that was stated.
By their numbers in this assay, from the lowest: compounds 2, 3 and 1 (each within the scatter of the next).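

On a sulfur whose other neighbour is a saturated chain carbon, 1,3-benzothiazol-2-yl in place of phenyl gives a 1.2-fold lower number from compound 1 to compound 3 (0.08 log units; within the scatter) in this assay. This position therefore accepts the two-ring group, with its two hydrogen-bond acceptors, without a shift beyond the scatter. No supporting measurement bears on this result.

Still open, on these data alone, is whether a methyl, or a group carrying an amine or a carboxylic acid, on this sulfur would move the number beyond the scatter. As far as these compounds go, the step's behaviour on other cores also remains unknown.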